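The source may hold more compounds than are shown below. What is called first, only, known or untested is meant among the compounds shown, and "the series" means these compounds.

Compounds measured so far:
compound 1, `C=C1CC[C@@H]2[C@](C)(CNCc3ccncc3)[C@H](O)CC[C@@]2(C)[C@@H]1/C=C/C1=CCOC1=O`: 2030 nM
compound 2, `C=C1CC[C@@H]2[C@](C)(CNCc3cccs3)[C@H](O)CC[C@@]2(C)[C@@H]1/C=C/C1=CCOC1=O`: 1070 nM

Both were tested in a functional assay on BMMC cells (Mus musculus, strain C57BL/6) for inhibition, with stated times of 5 days and 48 h; on this read-out higher numbers stand for weaker inhibition and lower numbers for stronger inhibition. Going by the values given here, compound 2 carries the lowest of the two numbers, and its nearest neighbour is compound 1; the only measured step, a 1.9-fold lower number from compound 1 to compound 2 (0.28 log units; within the scatter), stays within the scatter. Compound 3, `C=C1CC[C@H]2[C@@](C)(CC[C@@H](O)[C@@]2(C)C(=O)NCc2ccc(Br)cc2)[C@@H]1/C=C/C1=CCOC1=O`, has not yet been measured. It differs from compound 2 in one place: (4-bromobenzyl)carbamoyl in place of (((thiophen-2-yl)methyl)amino)methyl on a saturated ring carbon. Among the compounds with values here, no measured step touches this change, since the one recorded step swaps only the aromatic ring on the amine-bearing chain and leaves the chain itself unchanged. Compound 3 is therefore expected to land near compound 2, with a broad range: a 1.4-fold higher number from compound 2 to compound 3 (0.15 log units; within the scatter), giving an estimate of 1500 nM between 300 nM and 8000 nM.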

Compound 3, half-maximal inhibitory concentration: 3450 nM
For compound 3 the middle estimate is 2.3-fold (0.36 log units) below the measured one; low and high end bracket the measured number.
By their numbers in this assay, from the lowest: compounds 2, 1 and 3 (each within the scatter of the next, the first and the last beyond it).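

Going by these compounds alone, on this saturated ring carbon, the (4-bromobenzyl)carbamoyl group gives a 3.2-fold higher number from compound 2 to compound 3 (0.51 log units; beyond the scatter) in this assay and thus the first step beyond the scatter, while the matching replacement of the pyridin-4-yl chain gives a 1.7-fold higher number from compound 1 to compound 3 (0.23 log units; within the scatter) and stays within it. The same incoming group therefore separates clearly from only one of the two amine-bearing chains. Nothing available accounts for this difference. From the compounds shown here alone, both the linking carbonyl and the aromatic ring change together, so the contribution of each remains open. A (thiophen-2-yl)methyl amide or a 4-bromobenzyl amine at this carbon would separate them.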